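The source may hold more compounds than are shown below. What is called first, only, known or untested is meant among the compounds shown, and "the series" means these compounds.

Measured so far:
Compound 1, `O=C(CN(c1nc(Cl)nc2[nH]cnc12)C1CC1)NCC(=O)OCc1ccccc1`: in a functional assay on the whole organism (Tail, strain ICR) with Mus musculus as the target, in the tail flick test, with a stated time of 30 min, at a dose of 12.5 umol/kg by the oral route (a lower number here means a weaker effect, a higher number a stronger effect of the compound at the dose given), compound 1 gives 11.3%.
Compound 2, `CC(C)[C@H](NC(=O)CN(c1nc(Cl)nc2[nH]cnc12)C1CC1)C(=O)OCc1ccccc1`: in this assay compound 2 gives 16%.

Compound 2 sits at the top of this pair of numbers, but the step of a number 4.7 percentage points higher from compound 1 to compound 2 (within the scatter) is within the scatter, so the data do not separate the two. Compound 3 is `NCCCC[C@H](NC(=O)CN(c1nc(Cl)nc2[nH]cnc12)C1CC1)C(=O)OCc1ccccc1`. It differs from compound 2 in one place: 4-aminobutyl in place of isopropyl on a saturated chain carbon bound to an amide-type nitrogen and a carbonyl carbon. Among the measured compounds shown here, the only measured step touches the same saturated chain carbon bound to an amide-type nitrogen and a carbonyl carbon, and it came to a number 4.7 percentage points higher from compound 1 to compound 2 (within the scatter), within the scatter. On that single step, a change at this place has not moved the read-out beyond the scatter, and the 4-aminobutyl group is expected to behave the same way, though one step is slender support. Compound 3 is therefore estimated to give 16%, within 5% to 30%, in this assay. The expected step is thus no change at the digits printed from compound 2 to compound 3 (within the scatter).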

Compound 3, a percentage reported as activity, at one dose (the size of the read-out at that dose, not a potency): 18.5%
Compound 3: the middle estimate sits 2.5 percentage points below what was measured; the measured number falls inside the stated range.
By their numbers in this assay, from the lowest: compounds 1, 2 and 3 (each within the scatter of the next).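

With 4-aminobutyl in place of isopropyl on the saturated chain carbon bound to an amide-type nitrogen and a carbonyl carbon, this assay shows a number 2.5 percentage points higher from compound 2 to compound 3 (within the scatter), so a chain carrying a nitrogen is no more separable from isopropyl than isopropyl was from hydrogen. Measured against hydrogen directly, 4-aminobutyl gives a number 7.2 percentage points higher from compound 1 to compound 3 (within the scatter), which extends the earlier finding to a second group: neither substituent at this position separates from hydrogen in this read-out. No independent evidence bears on this result.

From the compounds shown here alone, it remains open whether a carboxylic acid or a phenyl ring on this same carbon would move the read-out beyond the scatter. Also open, going by these compounds, is whether these three compounds would separate at another dose or time.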